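Swapping a Thiophene for Methoxyphenyl in a Transporter Assay

This account rests on a few compounds, and the source may have more. Where it says the series, first, only, none or still open, it means among the compounds named here.

In an assay on CHO cells for inhibition of sodium-dependent dopamine transporter (Homo sapiens), read by scintillation counting, with a stated time of 10 min, tested at 10 uM (on this read-out lower numbers stand for less inhibition and higher numbers for more inhibition at the one concentration tested (going by the name of the read-out)), compound 1, with structure `OC(CCN1CC=C(Cc2ccccc2)CC1)c1cccs1`, gives 52%, the lowest of the three numbers recorded. Compound 2, `COc1ccc(C(O)CCN2CC=C(Cc3ccccc3)CC2)cc1OC`, gives 61% in this assay; these two values sit within the usual scatter of each other, so no difference between them can be claimed. Compound 3, `OC(CCN1CC=C(Cc2ccccc2)CC1)c1ccc(F)cc1F`, gives 66%, and the step of a number 14 percentage points higher from compound 1 to compound 3 (beyond the scatter) is a modest change that does lie beyond the scatter.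

Compound 4, `COc1ccc(C(O)CCN2CC=C(Cc3ccccc3)CC2)cc1`, has not yet been measured. It differs from compound 1 as follows: 4-methoxyphenyl in place of thiophen-2-yl on a saturated chain carbon bound to an oxygen on a saturated carbon and a saturated chain carbon. Among the measured compounds shown here, the step from compound 1 to compound 3 is the one measured change that bears on this, since it also replaces the thiophen-2-yl with a six-membered aromatic ring at the same place; the values of compound 1 and compound 2 show the same direction but remain within the scatter. A similar or smaller rise is therefore expected, with a number 8 percentage points higher from compound 1 to compound 4 (within the scatter) as the estimated step. Compound 4 is expected to give 60% in this assay, in the range 46% to 74%.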

Compound 4, a percentage reported as inhibition, at one concentration (the size of the read-out at that concentration, not a potency): 57%
Estimate against measurement, compound 4: 3 percentage points above; the range from low to high includes it.
By their numbers in this assay, from the lowest: compounds 1, 4, 2 and 3 (each within the scatter of the next, the first and the last beyond it).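

In this assay, 4-methoxyphenyl in place of thiophen-2-yl on this saturated chain carbon gives a number 5 percentage points higher from compound 1 to compound 4 (within the scatter), so a six-membered aromatic ring of carbon only does not by itself separate a compound from compound 1. Against the 2,4-difluorophenyl group, the same place gives a number 9 percentage points lower from compound 3 to compound 4 (within the scatter), and hydrogen in place of methoxy on an aromatic carbon gives a number 4 percentage points lower from compound 2 to compound 4 (within the scatter). Among the compounds shown here, compound 4 thus lies within the scatter of all three earlier compounds, and the only gap beyond the scatter remains the one between compound 1 and compound 3.

No measurement shown explains why these numbers fall as they do. Going by these compounds, whether an amine or a carboxylic acid on this aromatic ring would give a clearly different number remains open.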